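This account rests on a few compounds, and the source may have more. Where it says the series, first, only, none or still open, it means among the compounds named here.

Measured compounds:
- Compound 1, `O[C@H]1CCCC[C@@H]1Nc1nc(-c2ccccc2)nc2c1nnn2Cc1ccccc1`: 10300000 nM
- Compound 2, `OCCNc1nc(-c2ccccc2)nc2c1nnn2Cc1ccccc1`: 38000000 nM

In an assay on isolated protein for binding affinity to adenosine receptor A1 (Bos taurus) (on this read-out lower numbers stand for stronger inhibition and higher numbers for weaker inhibition), compound 2 gives 38000000 nM, the higher of the two numbers shown. Its nearest neighbour is compound 1, which in this assay gives 10300000 nM. Among the compounds with values here, the single step between them, a 3.7-fold higher number from compound 1 to compound 2 (0.57 log units; beyond the scatter), is modest but beyond the scatter.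

Compound 3, `OC1CCC(Nc2nc(-c3ccccc3)nc3c2nnn3Cc2ccccc2)CC1`, differs from compound 2 by 4-hydroxycyclohexyl in place of 2-hydroxyethyl on a nitrogen on an aromatic ring. Within the data shown here, only one measured step bears on this: a 3.7-fold higher number from compound 1 to compound 2 (0.57 log units; beyond the scatter), where replacing a hydroxycyclohexyl ring by the open 2-hydroxyethyl chain raised the number. Compound 3 restores a hydroxycyclohexyl ring, though with the hydroxyl in the position named above rather than that of compound 1, so a modest drop in the number is expected, of roughly the size seen from compound 1 to compound 2, not more.

For compound 3 the expected value in this assay is 12000000 nM, with a range of 3500000 nM to 45000000 nM, meaning an expected step of a 3.2-fold lower number from compound 2 to compound 3 (0.50 log units; beyond the scatter).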

Compound 3, inhibition constant: 2700000 nM
For compound 3 the middle estimate is 4.4-fold (0.65 log units) above the measured one; the whole stated range lies above it.
By their numbers in this assay, from the lowest: compound 3; then compound 1; then compound 2.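

At this nitrogen on an aromatic ring, a cyclohexyl ring does not by itself set the result: the place of its hydroxyl also counts. Putting 4-hydroxycyclohexyl in place of 2-hydroxyethyl gives a large change in this assay, a 14-fold lower number from compound 2 to compound 3 (1.15 log units; beyond the scatter), while 4-hydroxycyclohexyl in place of 2-hydroxycyclohexyl, with the hydroxyl moved around the same ring, still gives a 3.8-fold lower number from compound 1 to compound 3 (0.58 log units; beyond the scatter), so the earlier gain from the ring alone does not tell the whole story. Nothing available explains why the 4-hydroxycyclohexyl group gives the lowest number of the three.

The compounds shown leave open whether the hydroxyl is needed at all, as a plain cyclohexyl group would show. They also leave open how 3-hydroxycyclohexyl or 4-aminocyclohexyl would compare at this nitrogen.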